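The compounds below may be only part of what the source reports. "The series", "measured", "known", "first", "only" and "open" are said of these compounds alone.

Three compounds share one core and differ only in the group carried on a carbonyl carbon. Compound 1 `Cc1ccc(S(=O)(=O)N[C@@H](CC(=O)NC(C)(C)C)C(=O)NCCNC(=O)c2cc(C)ccc2F)cc1` bears a 2-fluoro-5-methylphenyl group there, compound 2 `Cc1ccc(S(=O)(=O)N[C@@H](CC(=O)NC(C)(C)C)C(=O)NCCNC(=O)NCc2ccccc2)cc1` a benzylamino group, and compound 3 `COc1cc(OC)cc(C(=O)NCCNC(=O)[C@H](CC(=O)NC(C)(C)C)NS(=O)(=O)c2ccc(C)cc2)c1` a 3,5-dimethoxyphenyl group. In an ADME assay on HepG2 cells (Homo sapiens) for cytotoxicity (on this read-out higher numbers stand for an effect only at larger amounts of compound and lower numbers for an effect already at smaller amounts), compound 1 gives only a limit, > 11000 nM. In this assay compound 2 likewise reaches only a limit, > 11000 nM. Compound 3 also stands at a limit in this assay, > 11000 nM. Because all three values sit at the limit of > 11000 nM in this assay, at which 3 of the 3 values shown sit, none of the steps among them can be read: a step that the two limits leave unreadable from compound 1 to compound 2, a step that the two limits leave unreadable from compound 1 to compound 3 and a step that the two limits leave unreadable from compound 2 to compound 3. Compound 4 `COc1cccc(C(=O)NCCNC(=O)[C@H](CC(=O)NC(C)(C)C)NS(=O)(=O)c2ccc(C)cc2)c1` differs from compound 3 by hydrogen in place of methoxy on an aromatic carbon. Going by the values given here, no measured step offers a readable size that bears on this change; the three measured compounds show only that each variation on the carbonyl carbon left the value at the limit of this assay. The step that the limit leaves unreadable from compound 3 to compound 4 is therefore expected to be small, with compound 4 most likely again at the limit. The estimate for compound 4 in this assay is 20000 nM, with a range from 9000 nM to 60000 nM.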

Compound 4, half-maximal effective concentration: > 11000 nM
Compound 4: only a limit was reported (the forecaster's own chance of this, stated with the estimate: 85%); the middle value lies beyond the limit too.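

In this assay, going by these compounds alone, compound 4 gives only a limit, as compound 1, compound 2 and compound 3 do, so no step from any of them to compound 4 can be read: the limit of > 11000 nM in this assay, at which 4 of the 4 values shown sit.

The compounds shown leave open how large these changes on the carbonyl carbon and the aromatic carbon are, and at what concentration any of the four compounds has an effect.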